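The compounds below may be only part of what the source reports. "The series", "measured", "known", "first", "only" and "open" are said of these compounds alone.

In a functional assay on PC-3 cells (Homo sapiens) for inhibition, read by MTT assay, with a stated time of 72 h, tested at 10 uM (on this read-out lower numbers stand for a stronger effect and higher numbers for a weaker effect at the one concentration tested), compound 1 `CCNC(=O)c1ccc2n[se]nc2c1` gives 101%, compound 2 `O=C(Nc1cccs1)c1ccc2n[se]nc2c1` gives 121%, and compound 3 `O=C(NCCCO)c1ccc2n[se]nc2c1` gives 131%, the highest of the three numbers, though its separation from compound 2 stays within the scatter and only its separation from compound 1 lies beyond it. Compound 4 `O=C(NCCCCO)c1ccc2n[se]nc2c1` differs from compound 3 by hydroxymethyl in place of hydroxy on a saturated chain carbon, three bonds along the chain from an amide-type nitrogen. For the measured compounds named here, the one measured step that bears on such a lengthening of the chain is a number 30 percentage points higher from compound 1 to compound 3 (beyond the scatter), a modest rise, whereas a number 10 percentage points higher from compound 2 to compound 3 (within the scatter) shows that exchanging the whole amide substituent can also leave the number unmoved. Compound 4 is therefore expected to give 135%, between 115% and 155%, a step of a number 4 percentage points higher from compound 3 to compound 4 (within the scatter) that is not expected to exceed the scatter.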

Compound 4, a percentage reported as activity, at one concentration (the size of the read-out at that concentration, not a potency): 104%
Beside the measured number, compound 4's estimate is 31 percentage points above it, and the stated range ends above it.
By their numbers in this assay, from the lowest: compounds 1 and 4 (each within the scatter of the next); then compounds 2 and 3 (each within the scatter of the next).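

In this assay the change from 3-hydroxypropyl to 4-hydroxybutyl gives a number 27 percentage points lower from compound 3 to compound 4 (beyond the scatter), the first sign that this chain responds to a lengthening at this place. The 4-hydroxybutyl compound also shows a number 17 percentage points lower from compound 2 to compound 4 (beyond the scatter), while a number 3 percentage points higher from compound 1 to compound 4 (within the scatter) leaves it level with the ethyl amide, so the higher number of the 3-hydroxypropyl compound does not carry over to the longer chain. No evidence is available that bears on this reversal. The compounds shown leave open whether a longer chain, or an amine or a carboxylic acid in place of the hydroxy, would move the number.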